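The source may report more compounds than this note shows. Statements on the series, on what has been measured and on what is new or still open speak of the compounds shown alone.

Measured compounds in a functional assay on NCI-H1299 cells (Homo sapiens) for antiproliferative activity, read by MTT assay, with a stated time of 48 h; on this read-out lower numbers stand for stronger inhibition and higher numbers for weaker inhibition:
Compound 1 `Cc1ccc2c(c1)C1(C(=O)N2C)C(C#N)=C(N)Oc2cc3oc(-c4ccccc4)cc(=O)c3c(O)c21` gives 10200 nM.
Compound 2 `Cc1ccc2c(c1)C1(C(=O)N2Cc2ccccc2)C(C#N)=C(N)Oc2cc3oc(-c4ccccc4)cc(=O)c3c(O)c21` gives > 50000 nM, which is a limit of the assay and not a number.
Compound 3 `Cc1cccc2c1N(Cc1ccccc1)C(=O)C21C(C#N)=C(N)Oc2cc3oc(-c4ccccc4)cc(=O)c3c(O)c21` gives > 50000 nM, which is likewise a limit of the assay.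

Compound 2 thus stands at the bound of this assay, the point described by the limit of > 50000 nM in this assay, at which 2 of the 3 values shown sit. Where its true number lies beyond that bound is not known. Compound 4 `COc1ccc2c(c1)C1(C(=O)N2Cc2ccccc2)C(C#N)=C(N)Oc2cc3oc(-c4ccccc4)cc(=O)c3c(O)c21` differs from compound 2 by methoxy in place of methyl on an aromatic carbon. The only step measured among these compounds, an at least 4.9-fold higher number from compound 1 to compound 2 (0.69 log units; beyond the scatter), concerns the group on the amide-type nitrogen in the ring rather than the aromatic substituent, so no measured step bears directly on the change from compound 2 to compound 4. With compound 2 already at the limit, no step beyond the scatter can be expected to show in this assay. The expected step that the limit leaves unreadable from compound 2 to compound 4 is accordingly one of no resolvable change, with compound 4 most likely reported as a limit again. Compound 4 is estimated at 60000 nM, within 20000 nM to 200000 nM in this assay.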

Compound 4, half-maximal inhibitory concentration: > 50000 nM
Compound 4: only a limit was reported; the forecaster's own chance of this, stated with the estimate: 80%; the middle value lies beyond the limit too.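

No step from compound 2 to compound 4 can be read in this assay, since the values of both compounds are limits of the assay and not numbers: the limit of > 50000 nM in this assay, at which 3 of the 4 values shown sit.

The compounds shown leave open whether methoxy in place of methyl on an aromatic carbon changes the read-out at all, and where the true numbers of compound 2 and compound 4 lie.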